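A Methyl on the Phenyl of Compound 3

The source may report more compounds than this note shows. Statements on the series, on what has been measured and on what is new or still open speak of the compounds shown alone.

Among the measured compounds shown here, the three compounds measured so far share one core and differ only in the group on the carbonyl carbon. In an assay on LtK cells with ATP-sensitive inward rectifier potassium channel 11 (Homo sapiens) as the target (on this read-out higher numbers stand for an effect only at larger amounts of compound and lower numbers for an effect already at smaller amounts), compound 1 `O=C(Nc1c(C(O)(C(F)(F)F)C(F)(F)F)ccc2ccccc12)C1CCCC1` gives 495 nM, compound 2 `O=C(CC1CCCC1)Nc1c(C(O)(C(F)(F)F)C(F)(F)F)ccc2ccccc12` gives 81 nM, and compound 3 `O=C(Nc1c(C(O)(C(F)(F)F)C(F)(F)F)ccc2ccccc12)c1ccccc1` gives 44 nM. The steps show a 6.1-fold lower number from compound 1 to compound 2 (0.79 log units; beyond the scatter) and an 11-fold lower number from compound 1 to compound 3 (1.05 log units; beyond the scatter), while a 1.8-fold lower number from compound 2 to compound 3 (0.27 log units; within the scatter) lies within the scatter, so compound 3 has the lowest number of the three but cannot be set apart from compound 2.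

Compound 4 `Cc1ccc(C(=O)Nc2c(C(O)(C(F)(F)F)C(F)(F)F)ccc3ccccc23)cc1` differs from compound 3 by methyl in place of hydrogen on an aromatic carbon. None of the three measured steps touches this kind of change: each swaps the whole group on the carbonyl carbon, and none adds methyl to an aromatic ring. The measured steps therefore bear on it only indirectly, showing that the phenyl compound sits at the low end of the series; a single methyl is a smaller alteration than any of those swaps. No step beyond the scatter is expected in this assay, the estimated move being a 1.1-fold lower number from compound 3 to compound 4 (0.04 log units; within the scatter). Compound 4 is therefore expected to give about 40 nM, with a range from 15 nM to 120 nM.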

Compound 4, half-maximal effective concentration: 76 nM
Compound 4: middle estimate off by 1.9-fold (0.28 log units), on the low side; the measured number falls inside the stated range.
By their numbers in this assay, from the lowest: compounds 3, 4 and 2 (each within the scatter of the next); then compound 1.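

Among the compounds shown here, on the phenyl of compound 3, a methyl on an aromatic carbon, para to a large group, is the first change that alters the ring without replacing the whole group on the carbonyl carbon, and in this assay the result is a 1.7-fold higher number from compound 3 to compound 4 (0.24 log units; within the scatter) and thus no separation between the two compounds. The 4-methylphenyl group also cannot be told apart from cyclopentylmethyl, with a 1.1-fold lower number from compound 2 to compound 4 (0.03 log units; within the scatter) as the step, but it stays clearly apart from cyclopentyl, with a 6.5-fold lower number from compound 1 to compound 4 (0.81 log units; beyond the scatter) as the step, so the distance from compound 1 seen with the unsubstituted phenyl also holds with this one added carbon. The data offer no measured explanation for any of these numbers.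

Only this one group at this one place on the ring is shown, so it remains open whether a methyl elsewhere on the ring would also stay within the scatter of compound 3. As far as these compounds go, it also remains open whether a larger or different group at the same place, such as a methoxy group, an amine, a carboxylic acid or a longer chain, would leave the number as little changed.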